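Chloro to nitro on the aryl ring: compound 3 to compound 4

The source may report more compounds than this note shows. Statements on the series, on what has been measured and on what is new or still open speak of the compounds shown alone.

In a functional assay on PC-3 cells (Homo sapiens) for antiproliferative activity, read by MTT assay, with a stated time of 72 h (a lower number here means a stronger inhibitor, a higher number a weaker inhibitor), compound 3 `O=C(COc1ccc(C(=O)/C=C/c2cccc(Cl)c2)cc1)N[C@H]1CCOC1=O` gives 4990 nM, the lowest of the two numbers shown. Its nearest neighbour, compound 1 `O=C(COc1ccc(C(=O)/C=C/c2cccc(Br)c2)cc1)N[C@H]1CCOC1=O`, gives 7890 nM in this assay, and the gap is a 1.6-fold lower number from compound 1 to compound 3 (0.20 log units; within the scatter). Compound 2 `O=C(COc1ccc(C(=O)/C=C/c2ccc(Br)cc2)cc1)N[C@H]1CCOC1=O` reaches only the limit of this assay, > 64000 nM, and is thus not a number (the limit of > 64000 nM in this assay, at which 1 of the 3 values shown sits). Compound 4 `O=C(COc1ccc(C(=O)/C=C/c2cccc([N+](=O)[O-])c2)cc1)N[C@H]1CCOC1=O` differs from compound 3 by nitro in place of chloro on an aromatic carbon. Among the measured compounds shown here, no measured step replaces a halogen with nitro on this aromatic carbon; the sole step on that carbon, bromo to chloro, stayed within the scatter. The 3-chlorophenyl to 3-nitrophenyl change is therefore expected to bring a 1.1-fold higher number from compound 3 to compound 4 (0.04 log units; within the scatter), a move not beyond the scatter. Compound 4 is estimated at 5500 nM, with a range of 1500 nM to 20000 nM.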

Compound 4, half-maximal inhibitory concentration: 56300 nM
Compound 4: the middle estimate sits 10-fold (1.01 log units) below what was measured; the measured number lies above the stated range.
By their numbers in this assay, from the lowest: compounds 3 and 1 (each within the scatter of the next); then compound 4. At a limit, above all of these: compound 2.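

In this assay, this aromatic carbon does not tolerate every group: chloro and bromo stayed within the scatter of each other, but nitro separates clearly from both, with an 11-fold higher number from compound 3 to compound 4 (1.05 log units; beyond the scatter) and a 7.1-fold higher number from compound 1 to compound 4 (0.85 log units; beyond the scatter). Against the 4-bromophenyl compound the comparison gives only an at least 1.1-fold lower number from compound 2 to compound 4 (0.05 log units; that floor lies within the scatter). The value of compound 2 is a limit and not a number: the limit of > 64000 nM in this assay, at which 1 of the 4 values shown sits.

Still open, going by these compounds, is whether an amine or a methoxy group on this carbon would stay with chloro and bromo or fall with nitro. With only these groups shown, no single trend across the position can be drawn.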